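Trifluoromethoxy in place of bromo on the fused ring

A few compounds are considered here, and "the series" means these few. Any claim that something is new, unique, unknown or untested is made for them only; others in the source may bear on it.

Compound 1 `C[C@@H]1COc2ccccc2[C@H](C)N1C(=O)c1ccc(Cl)cc1`: 6400 nM
Compound 2 `Cc1ccc2c(c1)[C@H](C)N(C(=O)c1ccc(Cl)cc1)[C@H](C)CO2`: 150 nM
Compound 3 `C[C@@H]1COc2ccc(Br)cc2[C@H](C)N1C(=O)c1ccc(Cl)cc1`: 430 nM

In a functional assay on CHO cells for antagonist activity at Orexin receptor type 2 (Homo sapiens), read by FLIPR and calcium flux (on this read-out higher numbers stand for weaker inhibition and lower numbers for stronger inhibition), compound 3 holds the second highest of the three numbers. Its nearest neighbour is compound 2, a 2.9-fold higher number from compound 2 to compound 3 (0.46 log units; beyond the scatter); the furthest is compound 1, a 15-fold lower number from compound 1 to compound 3 (1.17 log units; beyond the scatter). Compound 4 `C[C@@H]1COc2ccc(OC(F)(F)F)cc2[C@H](C)N1C(=O)c1ccc(Cl)cc1` differs from compound 3 in one place: trifluoromethoxy in place of bromo on an aromatic carbon. Among the compounds with values here, two measured steps bear on this position. Putting a group on that aromatic carbon of the shared core lowered the number strongly, as seen in a 43-fold lower number from compound 1 to compound 2 (1.63 log units; beyond the scatter) and a 15-fold lower number from compound 1 to compound 3 (1.17 log units; beyond the scatter), while exchanging one such group for another gave only a modest shift, a 2.9-fold higher number from compound 2 to compound 3 (0.46 log units; beyond the scatter). Swapping bromo for trifluoromethoxy is therefore expected to move the number by little, and in no clear direction beyond the scatter; the estimated step is a 1.1-fold lower number from compound 3 to compound 4 (0.03 log units; within the scatter). Compound 4 is expected to give 400 nM in this assay, within a range of 130 nM to 1300 nM.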

Compound 4, half-maximal inhibitory concentration: 140 nM
Estimate against measurement, compound 4: 2.9-fold (0.46 log units) above, and the stated range covers the measured number.
By their numbers in this assay, from the lowest: compounds 4 and 2 (each within the scatter of the next); then compound 3; then compound 1.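

In this assay the group on this aromatic carbon still matters once the carbon is substituted: trifluoromethoxy in place of bromo gives a 3.1-fold lower number from compound 3 to compound 4 (0.49 log units; beyond the scatter), a modest step but beyond the scatter. Trifluoromethoxy and methyl cannot be told apart here, with a 1.1-fold lower number from compound 2 to compound 4 (0.03 log units; within the scatter), while the large step from the unsubstituted core, a 46-fold lower number from compound 1 to compound 4 (1.66 log units; beyond the scatter), shows that trifluoromethoxy keeps the full gain seen with methyl, and compound 3 with bromo stands apart from both. No measurement shown accounts for the difference between bromo and the other two groups.

As far as these compounds go, whether an amine, a carboxylic acid or a longer alkoxy chain on this carbon would give a similar number remains open. So does whether the step from bromo to trifluoromethoxy would hold if the rest of the shared core were changed.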